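A few compounds are considered here, and "the series" means these few. Any claim that something is new, unique, unknown or untested is made for them only; others in the source may bear on it.

Compound 1 `CC(C)c1onc(-c2c(Cl)cccc2Cl)c1COc1ccc(-c2nc3cc(C(=O)O)ccc3n2C)cc1`: 25.8 nM
Compound 2 `CCCn1c(-c2ccc(OCc3c(-c4c(Cl)cccc4Cl)noc3C(C)C)cc2)nc2ccc(C(=O)O)cc21`: 9.3 nM

In an assay on Huh-7 cells for agonist activity at Bile acid receptor (Homo sapiens), read by a luciferase reporter (a lower number here means that less compound is needed, a higher number that more compound is needed for the effect), compound 2 gives the lower of the two numbers, and compound 1 stands higher by a gap beyond the scatter. For the measured compounds named here, compound 3 `CC(C)c1onc(-c2c(Cl)cccc2Cl)c1COc1ccc(-c2nc3ccc(C(=O)O)cc3n2CC2CCCCC2)cc1` differs from compound 2 by cyclohexyl in place of ethyl on a saturated chain carbon bound to an aromatic nitrogen; no step of this kind between two measured compounds is known here. Going from compound 1 to compound 2, a longer chain on the same nitrogen went with a lower number, so a still larger group is expected to give a number close to that of compound 2. The expected step is a 1.3-fold lower number from compound 2 to compound 3 (0.12 log units; within the scatter), within the scatter. Compound 3 is thus estimated at 7 nM, with a range from 2 nM to 25 nM.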

Compound 3, half-maximal effective concentration: 0.52 nM
Estimate against measurement, compound 3: 13-fold (1.13 log units) above; the whole stated range lies above it.
By their numbers in this assay, from the lowest: compound 3; then compound 2; then compound 1.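

In this assay, replacing the propyl on the aromatic nitrogen with cyclohexylmethyl gives an 18-fold lower number from compound 2 to compound 3 (1.25 log units; beyond the scatter). This position therefore accepts a six-membered non-aromatic ring of carbon, and in this pair the larger group goes with far less compound needed for the effect. Nothing available here explains why the number falls so sharply. The compounds shown leave open whether the ring itself matters or only the added carbon. A longer straight chain such as hexyl, or a benzyl group, on the same nitrogen would help separate the two.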